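This account rests on a few compounds, and the source may have more. Where it says the series, first, only, none or still open, it means among the compounds named here.

Series values in a functional assay on HT-1080 cells (Homo sapiens) for cytotoxicity, read by MTT assay, with a stated time of 72 h; on this read-out lower numbers stand for stronger inhibition and higher numbers for weaker inhibition:

- compound 1 `COc1ccc(/C=C2\CCC/C(=C\c3cccc(OC)c3OC)C2=O)cc1`: 16300 nM
- compound 2 `COc1ccc(/C=C2\CCC/C(=C\c3cccc(OC)c3OC)C2=O)c(OC)c1`: > 20000 nM (a limit)
- compound 3 `COc1ccc(/C=C2\CCC/C(=C\c3cccc(OC)c3OC)C2=O)cc1OC`: 6400 nM

Compound 1 at 16300 nM has the higher of the two actual numbers, and compound 3 is the nearest at 6400 nM. As far as these compounds go, compound 2 gives > 20000 nM, which is a limit and not a number, so its place relative to compound 1 stays open.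

The next compound is compound 4 `COc1cccc(/C=C2\CCC/C(=C\c3ccc(O)c(Cl)c3)C2=O)c1OC`, and the change is 3-chloro-4-hydroxyphenyl in place of 4-methoxyphenyl on a double-bonded chain carbon bound to a double-bonded ring carbon. The measured steps bear on this only indirectly. Both put methoxy in place of hydrogen on an aromatic carbon, and neither involves a hydroxy or chloro group. One is an at least 1.2-fold higher number from compound 1 to compound 2 (0.08 log units; that floor lies within the scatter), and the other is a 2.5-fold lower number from compound 1 to compound 3 (0.41 log units; beyond the scatter). These steps point in opposite directions, and only the second gives a full measured size. A modest move towards a lower number is therefore expected, resting on that second step, and the uncertainty is wide. The expected change is a 2.7-fold lower number from compound 1 to compound 4 (0.43 log units; beyond the scatter).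

For compound 4 the estimated value is 6000 nM, with an expected range of 1800 nM to 18000 nM.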

Compound 4, half-maximal inhibitory concentration: 14300 nM
Compound 4: the middle estimate sits 2.4-fold (0.38 log units) below what was measured, within the range that was stated.
By their numbers in this assay, from the lowest: compound 3; then compounds 4 and 1 (each within the scatter of the next). At a limit, above all of these: compound 2.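

In this assay, 3-chloro-4-hydroxyphenyl in place of 4-methoxyphenyl on a double-bonded chain carbon bound to a double-bonded ring carbon gives a 1.1-fold lower number from compound 1 to compound 4 (0.06 log units; within the scatter) and leaves the two values within the scatter of each other. Unlike the earlier steps, which only add a methoxy on an aromatic carbon, this one replaces the whole group at that place, bringing in a chlorine and a hydrogen-bond donor, and this read-out does not separate the two compounds. No measurement at hand speaks to why this exchange gives so small a step.

As far as these compounds go, the chloro and hydroxy groups arrive together here, so what each contributes alone at this place stays open, and a small step for the pair does not show that each alone would give a small step. Also open, from the compounds shown here alone, is whether a group of another kind on this ring, such as an amine or a carboxylic acid, would move the number beyond the scatter in either direction.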